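Methoxy to acetamido on the side chain

A few compounds are considered here, and "the series" means these few. Any claim that something is new, unique, unknown or untested is made for them only; others in the source may bear on it.

In an in vitro ADME assay on microsomes from liver (Rattus norvegicus) for metabolic stability (on this read-out lower numbers stand for a shorter-lived compound and higher numbers for a longer-lived compound), compound 1 `COCCN1CC[C@H](C)Nc2cc(ccc2C(N)=O)-n2c(c(C)c3c2CC(C)(C)CC3=O)CC1=O` reports only a limit, > 0.5 h. Compound 2 `CC(=O)NCC(=O)N1CCc2c(C)c3c(n2-c2ccc(C(N)=O)c(c2)N[C@@H](C)CC1)CC(C)(C)CC3=O` also reports only a limit, > 0.5 h. Compound 3 `Cc1c2c(n3c1CCN(C(=O)[C@@H](C)N)CC[C@H](C)Nc1cc-3ccc1C(N)=O)CC(C)(C)CC2=O` again reports only a limit, > 0.5 h. What these compounds share is the limit of > 0.5 h in this assay, at which 3 of the 3 values shown sit. Compound 4 `CC(=O)NCCN1CC[C@H](C)Nc2cc(ccc2C(N)=O)-n2c(c(C)c3c2CC(C)(C)CC3=O)CC1=O` differs from compound 1 by acetamido in place of methoxy on a saturated chain carbon, two bonds along the chain from an amide-type nitrogen in a ring. Going by the values given here, the only measured step is a step that the two limits leave unreadable from compound 2 to compound 3, and it offers no size to carry over. No direction follows from it, so no change beyond the scatter is expected in this assay, and the expected step is a step that the limit leaves unreadable from compound 1 to compound 4. For compound 4 the estimate is 0.7 h, with an expected range from 0.35 h to 1.5 h.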

Compound 4, half-life in the Rattus norvegicus assay: > 0.5 h
Compound 4: only a limit was reported; the forecaster's own chance of this, stated with the estimate: 80%; the middle value lies beyond the limit too.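

Going by these compounds alone, in the Rattus norvegicus assay and in a physicochemical assay for solubility (on this read-out higher numbers stand for higher solubility and lower numbers for lower solubility), compound 1 and compound 4 report only limits, so no step between them can be read. In the physicochemical assay compound 1 gives the limit > 100 ug/mL as its value. In the physicochemical assay compound 4 gives the limit > 100 ug/mL as its value. From the compounds shown here alone, how far either compound lies beyond those limits stays open.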